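A few compounds are considered here, and "the series" means these few. Any claim that something is new, unique, unknown or untested is made for them only; others in the source may bear on it.

The compounds share one core, carrying a cyclopropyl-bearing amine that is joined to an amino acid through a glycine-derived amide. Compound 1 `CC[C@H](C)[C@H](NC(=O)CN(c1nc(Cl)nc2[nH]cnc12)C1CC1)C(=O)O` is built on isoleucine, and in a functional assay on the whole organism (Tail, strain ICR) with Mus musculus as the target, in the tail flick test, with a stated time of 150 min, at a dose of 25 umol/kg by the oral route (on this read-out higher numbers stand for a stronger effect at the one dose given and lower numbers for a weaker effect), compound 1 gives 6.71%. Compound 2 `C[C@@H](O)[C@H](NC(=O)CN(c1nc(Cl)nc2[nH]cnc12)C1CC1)C(=O)O` carries threonine instead, and in this assay compound 2 gives 24%. Among the compounds with values here, the single change between them, hydroxy in place of ethyl on a saturated chain carbon bound to two saturated chain carbons, gives a number 17.3 percentage points higher from compound 1 to compound 2 (beyond the scatter). Among the two measured compounds, compound 1 therefore stands lowest in this assay, with compound 2 above it by a margin beyond the scatter.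

Compound 3 `CC[C@H](C)[C@H](NC(=O)CN(c1nc(Cl)nc2[nH]cnc12)C1CC1)C(=O)OCc1ccccc1` departs from compound 1 at the acid: benzyl in place of hydrogen on an oxygen next to a carbonyl group. Within the data shown here, no measured pair in this set shows the effect of closing the carboxy into an ester, and the only step known concerns the side chain, so no direction can be read from the data. He expects compound 3 to land near compound 1, with a number 5.3 percentage points higher from compound 1 to compound 3 (within the scatter) as his best guess. For compound 3 in this assay he estimates 12%, within a range from 0% to 35%.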

Compound 3, a percentage reported as activity, at one dose (the size of the read-out at that dose, not a potency): 6.9%
Compound 3: the middle estimate sits 5.1 percentage points above what was measured, and the stated range covers the measured number.
By their numbers in this assay, from the lowest: compounds 1 and 3 (each within the scatter of the next); then compound 2.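

At the acid, the difference from carboxy to benzyloxycarbonyl gives, in this assay, a number 0.2 percentage points higher from compound 1 to compound 3 (within the scatter). Within the data shown here, the only earlier step concerned the side chain and lay beyond the scatter, whereas this one shows that, on the isoleucine compounds at this one dose and time, the free carboxy and its benzyl ester cannot be told apart by this read-out. Nothing given here bears on why the two compounds read alike.

Left open is whether benzyl on the same oxygen would read the same way on the threonine side chain of compound 2, where the hydroxy sits in place of ethyl and the number starts higher. Going by these compounds, it is equally open how a methyl ester, an ethyl ester or a primary amide at this position would read, and whether the closeness of compound 1 and compound 3 would hold at other doses or times.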